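The source may report more compounds than this note shows. Statements on the series, on what has been measured and on what is new or still open speak of the compounds shown alone.

Of the compounds shown here, two built on a shared core have been measured so far in an ADME assay (liver) for metabolic stability, with Liver microsome (Homo sapiens) as the target, read by LC-MS, using microsomes, with a stated time of 30 min, tested at 4 uM; a higher number here means that more of the compound is left, a lower number that less of the compound is left. Compound 1 `Cc1nc(N2CCN(C)CC2)c2nc(-c3ccccc3Cl)n(CCO)c2n1` gives 13% and compound 2 `Cc1nc(N2CCN(C)CC2)c2nc(-c3cccc(C(F)(F)F)c3)n(C3CCOCC3)c2n1` gives 19% in the same test. These two values lie within the usual scatter of each other, so compound 2 stands level with compound 1 and neither can be ranked over the other.

The next compound is compound 3 `Cc1nc(N2CCN(C)CC2)c2nc(-c3ccccc3F)n(C3CCOCC3)c2n1`. It keeps the oxan-4-yl group of compound 2 and alters one substituent on an aromatic carbon of the five-membered aromatic ring, with 2-fluorophenyl in place of 3-(trifluoromethyl)phenyl on an aromatic carbon as the whole of the change.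

Going by the values given here, no measured pair shows this kind of swap on its own, so the data offer no direct guide to its size or direction. The only reference points are the two values above, which agree within the scatter. On that thin basis, no shift beyond the scatter is expected in this assay. The expected change is a number 1 percentage points higher from compound 2 to compound 3 (within the scatter) and it would stay within the scatter. Compound 3 is estimated at 20% (expected range 8% to 38%).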

Compound 3, percent of the compound remaining: 10%
The estimate for compound 3 lay 10 percentage points above the measured number; the measured number falls inside the stated range.
By their numbers in this assay, from the lowest: compounds 3, 1 and 2 (each within the scatter of the next).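

Going by these compounds alone, compound 2 and compound 3 are the first pair here that differ in one place. With the oxan-4-yl group held fixed, putting 2-fluorophenyl in place of 3-(trifluoromethyl)phenyl on the aromatic carbon between two ring nitrogen atoms gives a number 9 percentage points lower from compound 2 to compound 3 (within the scatter) in this assay, so this test does not tell these two phenyl groups apart at this position. Nothing available gives a measured reason for this result.

As far as these compounds go, it remains open whether a different kind of group on this carbon, such as a phenyl ring carrying a carboxylic acid or an amine, would move the number beyond the scatter. From the compounds shown here alone, it is also open whether the same swap would read the same way with a simple methyl group in place of oxan-4-yl on the ring atom that bears it.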